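The source may report more compounds than this note shows. Statements on the series, on what has been measured and on what is new or still open speak of the compounds shown alone.

Working notes on the urea series.

For the measured compounds named here, compound 2 `COc1cc(-c2nn(-c3cccc(NC(=O)Nc4ccc(Cl)c(Cl)c4)c3)cc2-c2ccncc2)ccc1Cl` gives the lowest of the two numbers so far: in a functional assay on Malme-3M cells (Homo sapiens) for inhibition, read by sulforhodamine B assay, with a stated time of 48 h (a higher number here means a weaker inhibitor of growth, a lower number a stronger inhibitor of growth), compound 2 gives 2420 nM. Compound 1 `O=C(Nc1cccc(-n2cc(-c3ccncc3)c(-c3ccc(Cl)c(O)c3)n2)c1)Nc1cccc(C(F)(F)F)c1` differs from it in two places and is the only comparator; in this assay compound 1 gives 20100 nM, a gap beyond the scatter, though the two structural changes cannot be separated on these numbers.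

Compound 3 `O=C(Nc1cccc(-n2cc(-c3ccncc3)c(-c3ccc(Cl)c(O)c3)n2)c1)Nc1ccc(Cl)c(Cl)c1` returns to the hydroxy of compound 1 while keeping the dichlorophenyl urea of compound 2. The change from compound 2: hydrogen in place of methyl on an oxygen on an aromatic ring. Going by the values given here, no single-change step is available to size this. Because compound 1 carries the same hydroxy and gives 20100 nM, some loss relative to compound 2 is expected. The step estimated is a 2.3-fold higher number from compound 2 to compound 3 (0.36 log units; beyond the scatter), kept smaller than the gap between compound 1 and compound 2. For compound 3 the expected value in this assay is 5500 nM, within 1800 nM to 17000 nM.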

Compound 3, concentration for total growth inhibition: 8100 nM
The estimate for compound 3 lay 1.5-fold (0.17 log units) below the measured number; the measured number falls inside the stated range.
By their numbers in this assay, from the lowest: compound 2; then compound 3; then compound 1.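

In this assay the change from methoxy to hydroxy on the 4-chloro-3-methoxyphenyl group can now be sized alone, with the 3,4-dichlorophenyl urea held fixed: the step is a 3.3-fold higher number from compound 2 to compound 3 (0.52 log units; beyond the scatter) in favour of the methoxy compound. With the 4-chloro-3-hydroxyphenyl group held fixed, 3,4-dichlorophenyl in place of 3-(trifluoromethyl)phenyl on an amide-type nitrogen gives a 2.5-fold lower number from compound 1 to compound 3 (0.39 log units; beyond the scatter) as the second step. Both steps run the same way along the path from compound 1 to compound 2, so the gap between those two compounds, which could not be divided earlier, now splits into two modest parts.

Still open, as far as these compounds go, is whether methoxy keeps its edge over hydroxy with the 3-(trifluoromethyl)phenyl urea, and whether an ethoxy group or an amine at this place would do better than methoxy. Nothing in hand accounts for either step.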